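Adding a second chloro to the urea phenyl ring

The compounds below may be only part of what the source reports. "The series", "measured", "known", "first", "only" and "open" are said of these compounds alone.

Compound 1 `CN(C)CCCNc1nc(-c2ccc(NC(=O)Nc3ccccc3Cl)cc2)nc2ccsc12` gives 390 nM in a functional assay on HT-29 cells (Homo sapiens) for cytotoxicity, read by MTT assay, with a stated time of 72 h; a higher number here means a weaker inhibitor, a lower number a stronger inhibitor.
Compound 2 `CN(C)CCCNc1nc(-c2ccc(NC(=O)Nc3ccc(Cl)cc3Cl)cc2)nc2ccsc12` gives 1860 nM in this assay.
Compound 3 `CCN(CC)CCCNc1nc(-c2ccc(NC(=O)Nc3ccccc3Cl)cc2)nc2c(Cl)c(Cl)sc12` gives 410 nM in this assay.

Compound 1 and compound 3 carry the same urea end but sit on different cores; the difference between the two cores is not broken down here. In this assay their two numbers lie within the usual scatter of each other. Going from compound 1 to compound 2 means (chloro in place of hydrogen on an aromatic carbon), and this gave a step of a 4.8-fold higher number from compound 1 to compound 2 (0.68 log units; beyond the scatter).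

Compound 4 `CCN(CC)CCCNc1nc(-c2ccc(NC(=O)Nc3ccc(Cl)cc3Cl)cc2)nc2c(Cl)c(Cl)sc12` has not yet been measured. It arises from compound 3 by the same change, (chloro in place of hydrogen on an aromatic carbon). Because the earlier step of a 4.8-fold higher number from compound 1 to compound 2 (0.68 log units; beyond the scatter) was a modest weakening, compound 4 is expected to show a similar step, a 4.4-fold higher number from compound 3 to compound 4 (0.64 log units; beyond the scatter), resting on that single precedent. Compound 4 is therefore estimated at 1800 nM, with a likely range from 700 nM to 4500 nM.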

Compound 4, half-maximal inhibitory concentration: 1230 nM
Beside the measured number, compound 4's estimate is 1.5-fold (0.17 log units) above it; low and high end bracket the measured number.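

In this assay, the chloro that turns 2-chlorophenyl into 2,4-dichlorophenyl gives a 3.0-fold higher number from compound 3 to compound 4 (0.48 log units; beyond the scatter), so the second core also ends up a weaker inhibitor. Set side by side, the two steps point the same way and do not differ in size beyond what repeated measurements would scatter: the same change on two cores in this assay, a 4.8-fold higher number (0.68 log units; beyond the scatter) from compound 1 to compound 2 and a 3.0-fold higher number (0.48 log units; beyond the scatter) from compound 3 to compound 4, 1.6-fold (0.20 log units) apart, within the scatter of two such steps. This is a match on just two cores in one cell assay, so it does not show that the change would behave alike on other cores, and it does not explain why the number rises.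

The compounds shown leave open whether a fluoro or a methoxy group in the same place on the ring would weaken the result as much. They also leave open how a chloro elsewhere on that ring would compare.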